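Isopropyl on the aromatic nitrogen of compound 2

A few compounds are considered here, and "the series" means these few. Any claim that something is new, unique, unknown or untested is made for them only; others in the source may bear on it.

Compound 1 `CCn1c(/C=C2\SC(=O)N(CC(=O)N3CC(C)OC(C)C3)C2=O)nc2ccccc21`: > 50000 nM (a limit, not a number)
Compound 2 `CC1CN(C(=O)CN2C(=O)S/C(=C\c3nc4ccccc4n3C)C2=O)CC(C)O1`: 29400 nM

For the measured compounds named here, in a functional assay on A549 cells (Homo sapiens) for inhibition, read by MTT assay, with a stated time of 48 h (on this read-out higher numbers stand for weaker inhibition and lower numbers for stronger inhibition), compound 2 gives 29400 nM, the only actual number so far. Compound 3 `CC1CN(C(=O)CN2C(=O)S/C(=C\c3nc4ccccc4n3C(C)C)C2=O)CC(C)O1` differs from compound 2 in one place: isopropyl in place of methyl on an aromatic nitrogen. Going by the values given here, one measured step bears on this, an at least 1.7-fold lower number from compound 1 to compound 2 (0.23 log units; that floor lies within the scatter), a change in the group on that same nitrogen. The smaller group goes with the lower number there, but that step's floor lies within the scatter, so only a modest move towards weaker inhibition is expected. The expected size of this move is a 1.4-fold higher number from compound 2 to compound 3 (0.15 log units; within the scatter). Compound 3 is estimated at 42000 nM, with a range of 18000 nM to 90000 nM.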

Compound 3, half-maximal inhibitory concentration: > 50000 nM
Compound 3 gave a limit, no number; the forecaster's own chance of this, stated with the estimate: 45%; middle value at least 1.1-fold (0.07 log units) from the limit.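

In this assay, as far as these compounds go, isopropyl in place of methyl on this aromatic nitrogen gives an at least 1.7-fold higher number from compound 2 to compound 3 (0.23 log units; that floor lies within the scatter) and so shows no gain from the larger group, though the true size of the step stays unknown. The step between compound 1 and compound 3 cannot be read, as both values are limits, and so far only the methyl of compound 2 gives a real number: the limit of > 50000 nM in this assay, at which 2 of the 3 values shown sit.

From the compounds shown here alone, whether a plain hydrogen on this nitrogen, or a chain carrying an amine or a carboxylic acid, would give a lower number stays open. So does how far past its limit compound 3 lies.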